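Removing one methyl group from compound 2

The source may report more compounds than this note shows. Statements on the series, on what has been measured and on what is new or still open speak of the compounds shown alone.

Measured in a functional assay on RKO cells (Homo sapiens) for cytotoxicity, read by resazurin assay, with a stated time of 72 h; a lower number here means a stronger inhibitor, a higher number a weaker inhibitor
- Compound 1 `c1ccc(Nc2nc(-n3cnc4ccccc43)cs2)cc1` gives > 100000 nM (a limit)
- Compound 2 `COc1ccc(Nc2nc(-n3c(C)nc4ccccc43)cs2)cc1` gives 52500 nM

Among the measured compounds shown here, compound 2, at 52500 nM, holds the only actual number in this assay so far. The other result is not a number, since compound 1 reaches only the limit (the limit of > 100000 nM in this assay, at which 1 of the 2 values shown sits).

Compound 3 `COc1ccc(Nc2nc(-n3cnc4ccccc43)cs2)cc1` changes compound 2 in one place, with hydrogen in place of methyl on an aromatic carbon, between two ring nitrogen atoms (hydrogen in place of methyl on an aromatic carbon). For the measured compounds named here, no measured pair isolates this change. Compound 1 also has hydrogen on that carbon, and its > 100000 nM is a limit. A small loss of strength is therefore expected, possibly no larger than the scatter. The expected change is a 1.3-fold higher number from compound 2 to compound 3 (0.12 log units; within the scatter). Compound 3 is estimated at 70000 nM, with an expected range of 25000 nM to 100000 nM.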

Compound 3, half-maximal inhibitory concentration: > 100000 nM
Compound 3 gave a limit, no number; the forecaster's own chance of this, stated with the estimate: 40%; at least 1.4-fold (0.15 log units) between middle value and limit.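

In this assay, the methyl group on the aromatic carbon between two ring nitrogen atoms now has a comparison of its own: hydrogen in its place gives an at least 1.9-fold higher number from compound 2 to compound 3 (0.27 log units; that floor lies within the scatter). The result for compound 3 is a limit, not a number, and it is the second such result: the limit of > 100000 nM in this assay, at which 2 of the 3 values shown sit. The step that puts methoxy in place of hydrogen, from compound 1 to compound 3, cannot be read, so compound 2, which carries the methyl group, remains the only compound shown with an actual number.

On these data alone, whether losing the methyl group costs more than the usual scatter stays open, with the true size of the step unknown. Also open, as far as these compounds go, is how a larger group on the same carbon, such as ethyl, or an amine there would read in this assay.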